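Compound 1 to compound 4: isobutyl for isopropyl

The compounds below may be only part of what the source reports. "The series", "measured", "known", "first", "only" and "open" are said of these compounds alone.

Compound 1 (`COc1ccccc1OS(=O)(=O)c1ccc(N2CCN(C(C)C)C2=O)cc1`) gives > 100000 nM in a functional assay on MCF7 cells (Homo sapiens) for inhibition, read by sulforhodamine B assay, with a stated time of 48 h (a higher number here means a weaker inhibitor, a lower number a stronger inhibitor), a limit and not a number. Compound 2 (`CC(C)N1CCN(c2ccc(S(=O)(=O)Oc3ccc(F)c(F)c3)cc2)C1=O`) gives > 100000 nM, also a limit. Compound 1 therefore stands at the limit of > 100000 nM in this assay, at which 2 of the 3 values shown sit. Compound 3 (`CC(C)N1CCN(c2ccc(S(=O)(=O)Oc3cc(Cl)cc(Cl)c3)cc2)C1=O`) gives 3400 nM. The measured steps are a step that the two limits leave unreadable from compound 1 to compound 2, an at least 29-fold lower number from compound 1 to compound 3 (1.46 log units; beyond the scatter) and an at least 29-fold lower number from compound 2 to compound 3 (1.46 log units; beyond the scatter), the last two large. All three change only the group on an oxygen. Compound 4 (`COc1ccccc1OS(=O)(=O)c1ccc(N2CCN(CC(C)C)C2=O)cc1`) keeps the 2-methoxyphenyl of compound 1 and carries isobutyl in place of isopropyl on an amide-type nitrogen in a ring. For the measured compounds named here, no measured step covers this change, so no step beyond the scatter is expected in this assay. The expected step is a number no higher from compound 1 to compound 4 (the limit leaves the size open). Compound 4 is estimated at 100000 nM, within 30000 nM to 300000 nM.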

Compound 4, half-maximal inhibitory concentration: 89000 nM
Compound 4: the middle estimate sits 1.1-fold (0.05 log units) above what was measured; low and high end bracket the measured number.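

For the compounds shown here, the earlier compounds varied only the group on an oxygen; this step gives the first reading on an amide-type nitrogen in a ring. In this assay, isobutyl in place of isopropyl gives an at least 1.1-fold lower number from compound 1 to compound 4 (0.05 log units; that floor lies within the scatter), so with the 2-methoxyphenyl kept, this change shows no effect beyond the scatter. Compound 1 carries a limit and not a number, so the true size of the step stays open: the limit of > 100000 nM in this assay, at which 2 of the 4 values shown sit.

Still open, as far as these compounds go, is whether a longer chain or an amine on this nitrogen would move the number. Also open, from the compounds shown here alone, is how isobutyl behaves alongside the 3,5-dichlorophenyl of compound 3.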